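The source may hold more compounds than are shown below. What is called first, only, known or untested is meant among the compounds shown, and "the series" means these compounds.

In a functional assay on HepG2 cells (Homo sapiens) for inhibition, read by MTT assay, with a stated time of 72 h (a lower number here means a stronger inhibitor, a higher number a weaker inhibitor), three compounds on one shared core have been measured, and they differ only in the group on an aromatic nitrogen. Compound 1 `Cc1cc2occ(-c3nc(-c4ccccc4)c(-c4ccccc4)n3-c3ccc([N+](=O)[O-])cc3)c(=O)c2cc1Cl` gives 25000 nM and compound 2 `COc1ccccc1-n1c(-c2coc3cc(C)c(Cl)cc3c2=O)nc(-c2ccccc2)c1-c1ccccc1` gives 12500 nM in this test of inhibition. Compound 3 `Cc1cccc(-n2c(-c3coc4cc(C)c(Cl)cc4c3=O)nc(-c3ccccc3)c2-c2ccccc2)c1` gives 6250 nM and stands clear of compound 1 only: the steps are a 4.0-fold lower number from compound 1 to compound 3 (0.60 log units; beyond the scatter) against a 2.0-fold lower number from compound 2 to compound 3 (0.30 log units; within the scatter) for its nearest neighbour.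

Compound 4 `Cc1ccc(-n2c(-c3coc4cc(C)c(Cl)cc4c3=O)nc(-c3ccccc3)c2-c2ccccc2)c(C)c1` carries 2,4-dimethylphenyl in place of 3-methylphenyl on an aromatic nitrogen. Within the data shown here, no measured step makes this exact change. The steps that leave 4-nitrophenyl are a 2.0-fold lower number from compound 1 to compound 2 (0.30 log units; within the scatter) and the larger one already given, but neither compound 3 nor compound 4 carries that group. The closer guide is a 2.0-fold lower number from compound 2 to compound 3 (0.30 log units; within the scatter) between two compounds without it, so in this assay no step beyond the scatter is expected, in either direction. The estimate means no change at the digits printed from compound 3 to compound 4 (within the scatter) as the expected step. The expected value for compound 4 is 6250 nM within a range of 2800 nM to 14000 nM in this estimate.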

Compound 4, half-maximal inhibitory concentration: 3120 nM
For compound 4 the middle estimate is 2.0-fold (0.30 log units) above the measured one, and the stated range covers the measured number.
By their numbers in this assay, from the lowest: compounds 4, 3, 2 and 1 (each within the scatter of the next, the first and the last beyond it).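

In this assay the change to 2,4-dimethylphenyl on the aromatic nitrogen gives a 2.0-fold lower number from compound 3 to compound 4 (0.30 log units; within the scatter) and so does not separate compound 4 from compound 3. Among these compounds, it does separate compound 4 from compound 2, a gap that compound 3 did not open: the data show a 4.0-fold lower number from compound 2 to compound 4 (0.60 log units; beyond the scatter) and also an 8.0-fold lower number from compound 1 to compound 4 (0.90 log units; beyond the scatter) as the widest step seen at this position so far. No measurement available here accounts for these differences.

Going by these compounds, all four compounds carry a substituted phenyl group on this nitrogen, so it stays open how an amine or a carboxylic acid on that ring, or a longer alkyl chain in place of it, would read in this test. It also stays open what each of the two methyl groups contributes, since neither 2-methylphenyl nor 4-methylphenyl appears among the compounds shown.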